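The source may report more compounds than this note shows. Statements on the series, on what has been measured and on what is new or still open speak of the compounds shown alone.

Compound 1 `COc1ccc(C2=C(c3cc(OC)c(OC)c(OC)c3)CC3CCCN3C2=O)cc1O`: > 100000 nM, a limit of the assay and not a number.
Compound 2 `COc1ccc(C2=C(c3ccc(SC)cc3)CC3CCCN3C2=O)cc1OC(=O)CNC(=O)OC(C)(C)C`: 6000 nM
Compound 3 `COc1ccc(C2=C(c3ccc(SC)cc3)CC3CCCN3C2=O)cc1Br`: 800 nM

In a functional assay on U-251 cells (Homo sapiens) for cytotoxicity (a higher number here means a weaker inhibitor of growth, a lower number a stronger inhibitor of growth), compound 3 gives 800 nM, the lower of the two actual numbers, and the gap to compound 2 lies beyond the scatter. The next structure, compound 4 `CSc1ccc(C2=C(c3ccc(O)cc3)C(=O)N3CCCC3C2)cc1`, changes a whole ring substituent: 4-hydroxyphenyl in place of 3-bromo-4-methoxyphenyl on a double-bonded ring carbon. In words, 4-hydroxyphenyl replaces 3-bromo-4-methoxyphenyl on a double-bonded ring carbon, so the bromine is lost.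

Among the compounds with values here, only one measured step involves that bromine: a 7.5-fold lower number from compound 2 to compound 3 (0.88 log units; beyond the scatter). It is modest, yet it shows that the number responds to what sits at this spot. Compound 1 also lacks the bromine, but it differs elsewhere as well, and its > 100000 nM is a limit, so it serves only as a loose warning.

The number is therefore expected to rise, by a step of similar size to the measured one. An estimated 8.8-fold higher number from compound 3 to compound 4 (0.94 log units; beyond the scatter) follows. For compound 4 the estimated value is 7000 nM, with an expected range of 1500 nM to 35000 nM.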

Compound 4, concentration for 50% growth inhibition: > 100000 nM
Compound 4 gave a limit, no number; the forecaster's own chance of this, stated with the estimate: 20%; middle value at least 14-fold (1.15 log units) from the limit.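

In this assay, replacing the whole ring gives an at least 120-fold higher number from compound 3 to compound 4 (2.09 log units; beyond the scatter), a far larger step than the only earlier one at this ring, a 7.5-fold lower number from compound 2 to compound 3 (0.88 log units; beyond the scatter). On these data alone, compound 4 sits at a limit of the assay and not at a number, so the full size of its step stays unknown: the limit of > 100000 nM in this assay, at which 2 of the 4 values shown sit. With the 4-(methylsulfanyl)phenyl group kept, the ring on this double-bonded ring carbon therefore matters greatly, and 4-hydroxyphenyl does not stand in for 3-bromo-4-methoxyphenyl.

This single step removes the bromine and the methoxy group and adds the hydroxy group, and the compounds shown do not tell these three changes apart. Also open, as far as these compounds go, is how this ring would read with a chlorine in place of the bromine, or with an amine in place of the hydroxy group.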